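Swapping a carboxylic acid for a tetrazole on compound 1

This account rests on a few compounds, and the source may have more. Where it says the series, first, only, none or still open, it means among the compounds named here.

Measured so far:
- compound 1 `CC(C)(C)[C@H]1CC[C@H](c2cc(-c3ccc(OC(F)(F)F)cc3)nn2Cc2ccc(C(=O)NCCC(=O)O)cc2)CC1`: 480 nM
- compound 2 `O=C(O)c1ccc(Cn2nc(C3CCCCC3)cc2-c2ccc(OC(F)(F)F)cc2)cc1`: 2000 nM
- compound 3 `O=C(O)CCNC(=O)c1ccc(Cn2nc(-c3ccc(OC(F)(F)F)cc3)cc2C2CCCCC2)cc1`: 3800 nM

In an assay on CHO cells for displacement of a labelled ligand from Glucagon receptor (Homo sapiens) (a higher number here means a weaker inhibitor, a lower number a stronger inhibitor), compound 1 gives the lowest of the three numbers. Compound 2 gives 2000 nM and compound 3 gives 3800 nM; both gaps to compound 1 are beyond the scatter, so compound 1 is the strongest inhibitor here. Going by the values given here, the only single-point step known is a 7.9-fold higher number from compound 1 to compound 3 (0.90 log units; beyond the scatter), and it concerns the saturated ring, not the acid end of the molecule.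

Compound 4 `CC(C)(C)[C@H]1CC[C@H](c2cc(-c3ccc(OC(F)(F)F)cc3)nn2Cc2ccc(C(=O)Nc3nn[nH]n3)cc2)CC1` differs from compound 1 at that other end: 2H-tetrazol-5-yl in place of 2-carboxyethyl on an amide-type nitrogen. Among the compounds with values here, no measured pair probes this exchange; compounds 2 and 3 differ in their acid-bearing side chain, and their values lie within the scatter of each other, which suggests this region tolerates change without large shifts. The tetrazole keeps a hydrogen-bond donor in place of the acid. For this assay the expected step is a 1.6-fold lower number from compound 1 to compound 4 (0.20 log units; within the scatter), that is little change or a slight gain. The estimate for compound 4 is therefore 300 nM, with a range from 80 nM to 1500 nM.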

Compound 4, half-maximal inhibitory concentration: 63 nM
Beside the measured number, compound 4's estimate is 4.8-fold (0.68 log units) above it; the measured number lies below the stated range.
By their numbers in this assay, from the lowest: compound 4; then compound 1; then compounds 2 and 3 (each within the scatter of the next).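

In this assay, exchanging the 2-carboxyethyl group on the amide-type nitrogen for 2H-tetrazol-5-yl gives a 7.6-fold lower number from compound 1 to compound 4 (0.88 log units; beyond the scatter), which shows that the group on this nitrogen can shift binding by more than the scatter. Going by these compounds alone, the only earlier single-place step, a 7.9-fold higher number from compound 1 to compound 3 (0.90 log units; beyond the scatter), concerned the saturated ring, so this is the first direct sign that the opposite end of the molecule matters as well. Compound 4 also holds no carboxylic acid and its new group has the same count of 5 heavy atoms as the old one, so on this core a carboxylic acid is not required for the lower number, although nothing measured here gives a reason for the shift.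

On these data alone, all of this rests on a single pair, so it remains open whether the same exchange would lower the number on the core of compound 3, which lacks the tert-butyl group. As far as these compounds go, it is also open whether the result is particular to the tetrazole, or whether a 1,2,4-triazole, a sulfonic acid or a shorter carboxymethyl chain on the same nitrogen would perform similarly.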